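This account rests on a few compounds, and the source may have more. Where it says the series, first, only, none or still open, it means among the compounds named here.

For the measured compounds named here, compound 1 (`Cc1c(C(F)F)nnc2sc(C(=O)NC3CN(c4ncc(C(F)(F)F)cn4)C3)c(N)c12`) is one of only two compounds measured so far in an ADME assay on brain (Rattus norvegicus) for protein binding; a lower number here means a smaller unbound share, a higher number a larger unbound share of the compound. In this assay compound 1 gives 0.062, the higher of the two numbers. Compound 2 (`Cc1c(Cl)nnc2sc(C(=O)NC3CN(c4cc(C(F)(F)F)ncc4Cl)C3)c(N)c12`) gives 0.01, and this gap lies beyond the usual scatter of repeated measurements. Going by the values given here, the two compounds differ in more than one place, so the gap cannot be tied to any single change, and no measured pair yet shows what one small edit does.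

Compound 3 (`Cc1c(CF)nnc2sc(C(=O)NC3CN(c4ncc(C(F)(F)F)cn4)C3)c(N)c12`) stays very close to compound 1: hydrogen in place of fluoro on a saturated chain carbon bound to an aromatic carbon and a fluorine atom. Hydrogen stands in place of fluoro on a saturated chain carbon bound to an aromatic carbon and a fluorine atom, so difluoromethyl becomes fluoromethyl. Among the compounds with values here, with no direct precedent, the best guide is compound 1 at 0.062, and a change this small is expected to leave the number within the scatter, perhaps slightly higher. The expected step is a 1.1-fold higher number from compound 1 to compound 3 (0.05 log units; within the scatter). For compound 3 the estimated value is 0.07, with an expected range from 0.035 to 0.13.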

Compound 3, unbound fraction: 0.085
Beside the measured number, compound 3's estimate is 1.2-fold (0.08 log units) below it; low and high end bracket the measured number.
By their numbers in this assay, from the lowest: compound 2; then compounds 1 and 3 (each within the scatter of the next).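

For the compounds shown here, this is the first comparison in this assay in which only one place differs, so a single edit can now be read on its own. Hydrogen in place of fluoro on a saturated chain carbon bound to an aromatic carbon and a fluorine atom, which turns difluoromethyl into fluoromethyl, comes with a 1.4-fold higher number from compound 1 to compound 3 (0.14 log units; within the scatter) and therefore cannot be told apart from repeat-to-repeat variation, so in this one pair the loss of a single fluorine leaves no clear mark on the unbound share. No measured evidence on the reason for this outcome is at hand.

The compounds shown leave open whether this tolerance extends to groups of a different kind at this place, such as an ethyl chain, a methoxy group or an amine, since one small edit says little about larger ones. Compound 2 differs from the other compounds in more than one place, so which of its differences goes with its much smaller number also remains unsettled.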